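The source may hold more compounds than are shown below. What is called first, only, known or untested is meant among the compounds shown, and "the series" means these compounds.

Compound 3 `COc1cccc(CNCCCNc2ccnc3cc(Oc4ccc(F)cc4)ccc23)c1O` is the least cytotoxic of the three measured compounds in an ADME assay on HepG2 cells (Homo sapiens) for cytotoxicity, read by luminescence, CellTiter-Glo and ATP content, with a stated time of 72 h (a lower number here means that less compound is needed, a higher number that more compound is needed for the effect), where compound 3 gives 11000 nM. Compound 2 `COc1ccc(Oc2ccc3c(NCCCNCc4cccc(OC)c4O)ccnc3c2)cc1` gives 5500 nM, and a 2.0-fold higher number from compound 2 to compound 3 (0.30 log units; within the scatter). Compound 1 `COc1ccc(-c2ccc3c(NCCCNCc4cccc(OC)c4O)ccnc3c2)cc1` gives 1600 nM; a 6.9-fold higher number from compound 1 to compound 3 (0.84 log units; beyond the scatter) and a 3.4-fold higher number from compound 1 to compound 2 (0.54 log units; beyond the scatter). Compound 4 `COc1cccc(CNCCCNc2ccnc3cc(CC4CCCCC4)ccc23)c1O` differs from compound 3 by cyclohexylmethyl in place of 4-fluorophenoxy on an aromatic carbon. For the measured compounds named here, the measured steps all exchange one aromatic substituent for another at this place and each was modest or within the scatter, so a cyclohexylmethyl group here has no close precedent among them. The estimate for compound 4 is therefore a 1.4-fold lower number from compound 3 to compound 4 (0.14 log units; within the scatter), with no direction favoured beyond the scatter. Compound 4 is expected to give 8000 nM in this assay, between 3000 nM and 25000 nM.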

Compound 4, half-maximal effective concentration: 970 nM
Compound 4: middle estimate off by 8.2-fold (0.92 log units), on the high side; measured number outside the range, below it.
By their numbers in this assay, from the lowest: compounds 4 and 1 (each within the scatter of the next); then compounds 2 and 3 (each within the scatter of the next).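

In this assay, this position can move the number further than the earlier aromatic exchanges did: an 11-fold lower number from compound 3 to compound 4 (1.05 log units; beyond the scatter) is a large step, and a 5.7-fold lower number from compound 2 to compound 4 (0.75 log units; beyond the scatter) also lies beyond the scatter. Yet a 1.6-fold lower number from compound 1 to compound 4 (0.22 log units; within the scatter) stays within the scatter, so a non-aromatic cyclohexylmethyl group reads the same as 4-methoxyphenyl, and only the two phenoxy compounds stand apart. Nothing available here accounts for this. From the compounds shown here alone, whether a benzyl or cyclohexyloxy group at this place would group with compound 1 and compound 4 or with the phenoxy compounds remains open, as does the effect of an amine or carboxylic acid on the ring.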